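Swapping the aryl sulfone of compound 1 for a thiophene

A few compounds are considered here, and "the series" means these few. Any claim that something is new, unique, unknown or untested is made for them only; others in the source may bear on it.

Three compounds sharing an indazole-derived sulfone core were measured in an assay on HeLa cells for displacement of a labelled ligand from 5-hydroxytryptamine receptor 6 (Homo sapiens); on this read-out lower numbers stand for stronger inhibition and higher numbers for weaker inhibition. Compound 1 `Cc1ccc(S(=O)(=O)c2n[nH]c3ccc(N4CCN(C)CC4)cc23)cc1` gives 4.9 nM, which is the second highest of the three numbers. Compound 3 `CCCn1nc(S(=O)(=O)c2cccc3ccccc23)c2cc(N3CCNCC3)ccc21`, the nearest to it, gives 2.2 nM, a lower number by a margin that lies beyond the usual scatter of this assay. Compound 2 `O=S(=O)(c1cccc(F)c1)c1n[nH]c2cccc(N3CCNCC3)c12`, the furthest, gives 134 nM, a much higher number; compound 2 differs from compound 1 in several places, so its two values show only that these differences together cost a great deal of binding.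

Compound 4 `CN1CCN(c2ccc3[nH]nc(S(=O)(=O)c4cccs4)c3c2)CC1` is not yet measured. It differs from compound 1 in one place: thiophen-2-yl in place of 4-methylphenyl on a sulfonyl sulfur. Among the measured compounds shown here, no measured pair in this set shows the effect of this exchange on its own, so nothing directly tells what it will do in this assay. Because compound 1 gives 4.9 nM and compound 3, carrying a different aryl group on the same sulfonyl sulfur, gives 2.2 nM, the aryl group on the sulfone appears to tolerate variation here. Compound 4 is therefore expected to remain close to compound 1, with a step from a 1.6-fold higher number from compound 1 to compound 4 (0.21 log units; within the scatter) that may be small and, if anything, towards a slightly higher number. The estimate for compound 4 in this assay is 8 nM, with a range from 2.5 nM to 25 nM.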

Compound 4, inhibition constant: 7.8 nM
The estimate for compound 4 lay 1.0-fold (0.01 log units) above the measured number; the measured number falls inside the stated range.
By their numbers in this assay, from the lowest: compound 3; then compounds 1 and 4 (each within the scatter of the next); then compound 2.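

In this assay, among the compounds shown here, the exchange of 4-methylphenyl for thiophen-2-yl on a sulfonyl sulfur gives a 1.6-fold higher number from compound 1 to compound 4 (0.20 log units; within the scatter) and is the first comparison in this set that isolates a single place. It shows that, with the rest of compound 1 unchanged, a six-membered aromatic ring of carbon only can give way to a five-membered aromatic ring with one sulfur, with two fewer heavy atoms and without the methyl group, and the two numbers remain within the scatter of each other. The 4-methylphenyl group is therefore not needed to hold the number at this level in this series, although that conclusion rests on this one pair, and nothing measured on the two groups explains the result.

The compounds shown leave open whether a plain phenyl, a furan-2-yl or a pyridine ring would also stay close to compound 1, and whether an aryl ring carrying an amine or a carboxylic acid would do so. They also leave open whether the same exchange would behave alike on the core of compound 2 or compound 3, whose other differences from compound 1 may change what this position tolerates.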